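The source may hold more compounds than are shown below. What is called first, only, known or untested is meant among the compounds shown, and "the series" means these compounds.

Of the compounds shown here, two have been tested in an assay on microsomes from placenta for inhibition of 17-beta-hydroxysteroid dehydrogenase type 2 (Homo sapiens), read by HPLC, with a stated time of 20 min; a higher number here means a weaker inhibitor, a lower number a stronger inhibitor. Compound 1 `COc1cccc(N(C)C(=O)C2CCC(c3ccc(Cl)cc3)CC2)c1` gives 290 nM in that assay. Compound 2 `Cc1ccc(Oc2ccc(C(=O)N(C)c3cccc(C)c3)cc2)cc1` gives 160 nM in this assay. Compound 2 thus shows the lower of the two numbers, though its gap to compound 1 lies within the usual scatter, so the two cannot be ranked against each other. Compound 3 `Cc1cccc(Oc2ccc(C(=O)N(C)c3cccc(C)c3)cc2)c1` has not yet been measured. It differs from compound 2 in one place: 3-methylphenyl in place of 4-methylphenyl on an oxygen on an aromatic ring. For the measured compounds named here, no step between two measured compounds of this kind is available, so the effect of this change has no precedent in the data. The step of a 1.3-fold higher number from compound 2 to compound 3 (0.10 log units; within the scatter) is expected to stay within the scatter, with no clear direction either way. For compound 3 the estimate in this assay is 200 nM, with a range from 60 nM to 700 nM.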

Compound 3, half-maximal inhibitory concentration: 300 nM
For compound 3 the middle estimate is 1.5-fold (0.18 log units) below the measured one; the measured number falls inside the stated range.
By their numbers in this assay, from the lowest: compounds 2, 1 and 3 (each within the scatter of the next).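

For the compounds shown here, this pair gives the first step in the data at this position: with 3-methylphenyl in place of 4-methylphenyl on an oxygen on an aromatic ring, this assay shows a 1.9-fold higher number from compound 2 to compound 3 (0.27 log units; within the scatter). Since the step lies within the scatter, the assay does not tell these two methylphenyl groups apart, and neither group can be ranked above the other. Nothing in hand offers an explanation for this result.

The compounds shown leave open whether a different group on this ring, such as a fluorine, a methoxy, an amine or a carboxylic acid, would give a step beyond the scatter from compound 2. They also leave open how an unsubstituted phenyl would compare with the two methylphenyl groups at this position.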